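Swapping the Aryl Ether Tail of a Weak Hydrazide

The source may hold more compounds than are shown below. What is called first, only, known or untested is meant among the compounds shown, and "the series" means these compounds.

Compound 1, with the structure `O=C(NNC(=O)C1CC1c1ccc(OC(F)(F)F)cc1)c1ccncc1`, was tested in a functional assay on PC-3 cells (Homo sapiens) for inhibition, read by MTT assay, with a stated time of 72 h; a lower number here means a stronger inhibitor, a higher number a weaker inhibitor. In this assay compound 1 gives > 100000 nM, which is a limit of the assay rather than a measured number; the only thing known is the limit of > 100000 nM in this assay, at which 1 of the 2 values shown sits. Within the data shown here, a second compound, compound 2, with the structure `O=C(NNc1nncc2ccccc12)C1CC1c1ccc(OCC(F)(F)F)cc1`, reaches a measured value in this assay of 67000 nM, and no single-point step connects the two.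

The unmeasured compound 3, with the structure `CC(C)=CCOc1ccc(C2CC2C(=O)NNC(=O)c2ccncc2)cc1`, differs from compound 1 in one place: 3-methylbut-2-en-1-yl in place of trifluoromethyl on an oxygen on an aromatic ring. Among the measured compounds shown here, no measured pair shows what this exchange does, so the expected step from compound 1 to compound 3, an at least 1.2-fold lower number from compound 1 to compound 3 (0.09 log units; that floor lies within the scatter), is taken as small and without a clear direction, beyond the scatter only by chance. Compound 3 is therefore expected to give about 80000 nM in this assay, with a range from 30000 nM to 200000 nM, and a good chance that the assay again reports only a limit.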

Compound 3, half-maximal inhibitory concentration: > 100000 nM
Compound 3 gave a limit, no number; the forecaster's own chance of this, stated with the estimate: 55%; middle value at least 1.2-fold (0.09 log units) away from the limit.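

In this assay compound 3 gives only a limit of the assay, not a number: the limit of > 100000 nM in this assay, at which 2 of the 3 values shown sit.

Compound 1 also gives a limit, so no step can be read between compound 1 and compound 3. The compounds shown leave open what 3-methylbut-2-en-1-yl in place of trifluoromethyl on this oxygen does to the strength of inhibition.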